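This account rests on a few compounds, and the source may have more. Where it says the series, first, only, none or still open, it means among the compounds named here.

Working notes on the series. In a functional assay on MCF7 cells (Homo sapiens) for inhibition, read by colorimetric assay and MTT assay, with a stated time of 72 h (on this read-out higher numbers stand for weaker inhibition and lower numbers for stronger inhibition), compound 1 `C=CCCCCCOc1ncc(-c2ccccc2OCCCCC=C)n1C` gives 63000 nM. Compound 2 `Cn1c(-c2ccccc2O)cnc1S(=O)(=O)c1ccccc1` reads > 100000 nM, which is a limit of the assay and not a number. Going by the values given here, the series so far therefore holds one number and (the limit of > 100000 nM in this assay, at which 1 of the 2 values shown sits).

Compound 3 `C=CCCCCOc1ccccc1-c1cnc(S(=O)(=O)c2ccccc2)n1C` differs from compound 2 by a single change, (hex-5-en-1-yl in place of hydrogen on an oxygen on an aromatic ring). In words, this is hex-5-en-1-yl in place of hydrogen on an oxygen on an aromatic ring, or hydroxy to (hex-5-en-1-yl)oxy. Among the compounds with values here, no measured pair isolates this change, so its size in this assay is not yet known.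

The expectation rests on compound 1, which also carries hex-5-en-1-yl on an oxygen on an aromatic ring and gives 63000 nM. A modest move toward stronger inhibition is therefore expected, with a readout that stays weak. The expected step is an at least 2.0-fold lower number from compound 2 to compound 3 (0.30 log units; that floor lies within the scatter). For compound 3 the estimate is 50000 nM, with an expected range of 15000 nM to 100000 nM.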

Compound 3, half-maximal inhibitory concentration: 25000 nM
The estimate for compound 3 lay 2.0-fold (0.30 log units) above the measured number; the range from low to high includes it.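

In this assay the change from hydroxy to (hex-5-en-1-yl)oxy now has a size, with an at least 4.0-fold lower number from compound 2 to compound 3 (0.60 log units; beyond the scatter) as its reading on this oxygen on an aromatic ring. That size is only a floor, since the reading of compound 2 is a limit of the assay and not a number: the limit of > 100000 nM in this assay, at which 1 of the 3 values shown sits. On the aromatic carbon, phenylsulfonyl in place of (hept-6-en-1-yl)oxy gives a 2.5-fold lower number from compound 1 to compound 3 (0.40 log units; beyond the scatter) and so shows that the group at this second place also moves the read-out, with the lower number on the phenylsulfonyl side.

The compounds shown carry only hex-5-en-1-yl on this oxygen, so they leave open whether the step follows from the chain as a whole or from its double bond, which a saturated hexyl chain, a shorter methyl group or a longer chain would separate. Also open, as far as these compounds go, is whether a polar end on the chain, such as an amine or a carboxylic acid, keeps the step, and whether any group on the aromatic carbon goes further than phenylsulfonyl.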